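This account rests on a few compounds, and the source may have more. Where it says the series, first, only, none or still open, it means among the compounds named here.

In a physicochemical assay for lipophilicity, using the shake flask method, at pH 7.4 (on this read-out lower numbers stand for lower lipophilicity and higher numbers for higher lipophilicity), compound 1 `CCc1c[nH]c2ncnc(N[C@H]3CC[C@H](N(C)C)CC3)c12` gives 0.6 and compound 2 `CN(C)[C@H]1CC[C@H](Nc2ncnc3[nH]cc(C4CC4)c23)CC1` gives 0.9, so these two stand within the usual scatter of each other. Compound 3 `CN(C)[C@H]1CC[C@H](Nc2ncnc3[nH]cc(C4CCCC4)c23)CC1` differs from compound 2 in one place: cyclopentyl in place of cyclopropyl on an aromatic carbon. In words, this is cyclopentyl in place of cyclopropyl on an aromatic carbon. Among the measured compounds shown here, only one measured step bears on this change, since it also swaps the group on an aromatic carbon: a number 0.30 log units higher from compound 1 to compound 2 (within the scatter). That step is small and gives only a weak guide. The entering group holds more carbon and brings no hydrogen-bond donors or acceptors, so a rise beyond the scatter is expected in this assay. The estimated size and direction of the change are a number 0.70 log units higher from compound 2 to compound 3 (beyond the scatter). For compound 3 the estimated value is 1.6, with an expected range from 1.2 to 2.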

Compound 3, distribution coefficient: 1.7
The estimate for compound 3 lay 0.10 log units below the measured number; the range from low to high includes it.
By their numbers in this assay, from the lowest: compounds 1 and 2 (each within the scatter of the next); then compound 3.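

At this position, on an aromatic carbon of the five-membered ring, the swap of cyclopropyl for cyclopentyl moves the number in this assay clearly beyond the scatter (a number 0.80 log units higher from compound 2 to compound 3 (beyond the scatter)), which the earlier swap of ethyl for cyclopropyl did not do. Measured against ethyl, the effect of cyclopentyl is larger still (a number 1.10 log units higher from compound 1 to compound 3 (beyond the scatter)), so compound 3 stands apart from both compound 1 and compound 2, while those two stay within the scatter of each other. No measurement in hand explains the size of these steps.

Going by these compounds, whether the number keeps rising with a bigger ring such as cyclohexyl remains open. So does how far it would fall back with a ring of similar size that carries an oxygen atom, such as tetrahydropyranyl, or with a hydroxyl on the cyclopentyl ring.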